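A few compounds are considered here, and "the series" means these few. Any claim that something is new, unique, unknown or untested is made for them only; others in the source may bear on it.

Of the compounds shown here, three built on one shared core have been tested in a functional assay on JAR cells (Homo sapiens) for inhibition, read by MTT assay, with a stated time of 72 h, tested at 10 uM; on this read-out lower numbers stand for less inhibition and higher numbers for more inhibition at the one concentration tested (going by the name of the read-out). Compound 1 `CCOC(=O)C1=C(Nc2ccccc2)S/C(=C\c2ccc([N+](=O)[O-])c(O)c2)C1=O` gives 51.2%, compound 2 `CCOC(=O)C1=C(Nc2ccccc2)S/C(=C\c2ccc(Br)c(O)c2)C1=O` gives 39.8%, and compound 3 `CCOC(=O)C1=C(Nc2ccc([N+](=O)[O-])cc2)S/C(=C\c2ccc[nH]2)C1=O` gives 54.9%. Compound 2 stands lowest of the three, with compound 1 nearest and compound 3 furthest, both beyond the scatter above it. Going by the values given here, the single step that can be read directly is a number 11.4 percentage points lower from compound 1 to compound 2 (beyond the scatter).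

Compound 4 `CCOC(=O)C1=C(Nc2ccccc2)S/C(=C\c2cc3ncccc3[nH]2)C1=O` has not yet been measured. Its change from compound 2 is a group of 9 heavy atoms (7 carbon, 2 nitrogen; one five-membered aromatic ring with 1 hetero atom, one six-membered aromatic ring with 1 hetero atom) in place of a group of 8 heavy atoms (6 carbon, 1 oxygen, 1 bromine; one six-membered aromatic ring of carbon only), on a double-bonded chain carbon bound to a double-bonded ring carbon. Among the compounds with values here, no measured step bears directly on this change: the one known step alters only a substituent on the ring that here leaves altogether, and compound 3, which carries a five-membered aromatic ring in that position, also differs elsewhere, so its value of 54.9% is only a loose guide. The step is expected to be a number 8.2 percentage points higher from compound 2 to compound 4 (within the scatter), upward, but with wide uncertainty. Compound 4 is therefore estimated at 48%, within a range from 30% to 66%.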

Compound 4, a percentage reported as inhibition, at one concentration (the size of the read-out at that concentration, not a potency): 74.8%
The estimate for compound 4 lay 26.8 percentage points below the measured number, outside the stated range (above it).
By their numbers in this assay, from the lowest: compound 2; then compounds 1 and 3 (each within the scatter of the next); then compound 4.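

In this assay, going by these compounds alone, the new step is a number 35 percentage points higher from compound 2 to compound 4 (beyond the scatter), and it is large, whereas the only earlier step at this part of the molecule, a number 11.4 percentage points lower from compound 1 to compound 2 (beyond the scatter), is modest. The group on the double-bonded chain carbon can therefore shift the number substantially, and a six-membered aromatic ring of carbon only is not required there: a group with a five-membered and a six-membered aromatic ring, each with one hetero atom, can take its place and give a higher number. No evidence here explains this rise.

The change replaces the whole group at once, so the compounds shown cannot separate the contributions of its two rings or two nitrogens. As far as these compounds go, how an amine or a carboxylic acid on the new group would affect the number also remains open.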